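Fluoro for hydrogen on two related cores

A few compounds are considered here, and "the series" means these few. Any claim that something is new, unique, unknown or untested is made for them only; others in the source may bear on it.

Compound 1 `O=C(Nc1ccccc1)c1ccc(C(=O)O)nc1` and compound 3 `O=C(Nc1ccc(C(=O)O)nc1)c1ccccc1` hold the same atoms joined differently; the difference between the two cores is not broken down here. In an assay on isolated protein (Gallus gallus) for inhibition of transmembrane prolyl 4-hydroxylase (Homo sapiens) (on this read-out lower numbers stand for stronger inhibition and higher numbers for weaker inhibition), compound 1 gives 26500 nM and compound 3 gives 25600 nM, two numbers within the scatter of each other. Compound 2 `O=C(Nc1ccccc1F)c1ccc(C(=O)O)nc1` carries the change fluoro in place of hydrogen on an aromatic carbon on the core of compound 1; in this assay compound 2 gives 11000 nM, and the step is a 2.4-fold lower number from compound 1 to compound 2 (0.38 log units; beyond the scatter). Compound 4 `O=C(O)c1ccc(NC(=O)c2ccccc2F)cn1` carries the same kind of change on the core of compound 3, (fluoro in place of hydrogen on an aromatic carbon); the two place descriptions read alike. Within the data shown here, the step from compound 3 to compound 4 in this assay is expected to be a 2.1-fold lower number from compound 3 to compound 4 (0.33 log units; beyond the scatter), resting on the single measured instance a 2.4-fold lower number from compound 1 to compound 2 (0.38 log units; beyond the scatter) and on compound 3 starting at 25600 nM. In this assay compound 4 is accordingly estimated at 12000 nM, within a range from 5000 nM to 30000 nM.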

Compound 4, half-maximal inhibitory concentration: 33800 nM
Estimate against measurement, compound 4: 2.8-fold (0.45 log units) below, and the stated range ends below it.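

In this assay, the change of fluoro in place of hydrogen on an aromatic carbon does not carry over from the core of compound 1 to the core of compound 3, giving a 1.3-fold higher number from compound 3 to compound 4 (0.12 log units; within the scatter). The two steps differ: the same change on two cores in this assay, a 2.4-fold lower number (0.38 log units; beyond the scatter) from compound 1 to compound 2 and a 1.3-fold higher number (0.12 log units; within the scatter) from compound 3 to compound 4, 3.2-fold (0.50 log units) apart, beyond the scatter of two such steps. For this change, the step on one core is therefore no reliable guide to the step on the other, but with a single pair on each core this does not show what sets the cores apart or whether other changes would diverge in the same way.

From the compounds shown here alone, it remains open whether chloro or methoxy in place of the same hydrogen would follow the step seen on the core of compound 1 or that seen on the core of compound 3.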